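This account rests on a few compounds, and the source may have more. Where it says the series, first, only, none or still open, it means among the compounds named here.

Compound 1 `CCCCN(C)c1nc(C(C)(C)C)ccc1CNC(=O)C(C)c1ccc(NS(C)(=O)=O)c(F)c1` gives 1.2 nM in an assay on cells for antagonist activity at transient receptor potential cation channel subfamily V member 1 (Homo sapiens), read by FLIPR and calcium flux, with a stated time of 6 min; a higher number here means a weaker inhibitor, a lower number a stronger inhibitor.
Compound 2 `CC(C(=O)NCc1ccc(C(C)(C)C)nc1N1CCCC1)c1ccc(NS(C)(=O)=O)c(F)c1` gives 1.2 nM in this assay.
Compound 3 `CC(C)CCOc1nc(C(C)(C)C)ccc1CNC(=O)C(C)c1ccc(NS(C)(=O)=O)c(F)c1` gives 0.8 nM in this assay.

Compound 3 holds the lowest of the three numbers, but it is not set apart: the steps of a 1.5-fold lower number from compound 1 to compound 3 (0.18 log units; within the scatter) and a 1.5-fold lower number from compound 2 to compound 3 (0.18 log units; within the scatter) both sit within the scatter, and no change at the digits printed from compound 1 to compound 2 (within the scatter) is no change either. Three different groups on the aromatic carbon next to the ring nitrogen, ortho to a large group and meta to the tert-butyl group, therefore give values that cannot be told apart in this assay.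

Compound 4 `CC(C(=O)NCc1ccc(C(C)(C)C)nc1SCCCN(C)C)c1ccc(NS(C)(=O)=O)c(F)c1` takes the same position one step further: (3-(dimethylamino)propyl)sulfanyl in place of isopentyloxy on an aromatic carbon

Among the compounds with values here, the steps that bear on it are the three exchanges at this carbon, all within the scatter, whether the group entering was butyl(methyl)amino, pyrrolidin-1-yl or isopentyloxy. The (3-(dimethylamino)propyl)sulfanyl group is of similar size to those already tried. On that basis no step beyond the scatter is expected, with the estimate for compound 4 being a 1.9-fold higher number from compound 3 to compound 4 (0.27 log units; within the scatter) relative to compound 3. Compound 4 is therefore expected to give about 1.5 nM in this assay, with a range from 0.5 nM to 5 nM.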

Compound 4, inhibition constant: 51.8 nM
Beside the measured number, compound 4's estimate is 35-fold (1.54 log units) below it; the measured number lies above the stated range.
By their numbers in this assay, from the lowest: compounds 3, 1 and 2 (each within the scatter of the next); then compound 4.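

The exchanges at this carbon are not all equivalent in this assay: where the three earlier groups could not be told apart, (3-(dimethylamino)propyl)sulfanyl gives a 65-fold higher number from compound 3 to compound 4 (1.81 log units; beyond the scatter) and likewise a 43-fold higher number from compound 2 to compound 4 (1.64 log units; beyond the scatter) and a 43-fold higher number from compound 1 to compound 4 (1.64 log units; beyond the scatter), so the step is large whichever group leaves. The position therefore tolerates an ether chain and both amines shown, but not this sulfur-linked chain with its dimethylamino end. No measurement given here accounts for the step.

Because the sulfur link and the dimethylamino end enter together, the compounds shown do not say which of them goes with the step. As far as these compounds go, a plain butylsulfanyl chain and a 3-(dimethylamino)propoxy chain on this carbon would separate the two, and a shorter or longer chain ending in the same amine remains open as well.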